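This account rests on a few compounds, and the source may have more. Where it says the series, first, only, none or still open, it means among the compounds named here.

In an assay on isolated protein for inhibition of Leucine-rich repeat serine/threonine-protein kinase 2 (Homo sapiens), read by TR-FRET and LanthaScreen, with stated times of 50 min and 30 min, in the presence of a further agent that is not named here (on this read-out higher numbers stand for weaker inhibition and lower numbers for stronger inhibition), compound 1 `Cn1c(N2CCCC2)c(C#N)c2c(N)ncnc21` gives 1480 nM. Compound 2 `Cc1cn(C)nc1Nc1cc2c(c(N)n1)c(C#N)c(N1CCC[C@H]1C)n2C` carries a methyl-bearing saturated ring but also a further group on the shared core; in this assay compound 2 gives 2110 nM. The two numbers lie within the scatter of one another, so on these figures compound 1 cannot be set apart from compound 2. Compound 3 `C[C@@H]1CCCN1c1c(C#N)c2c(N)ncnc2n1C` has not yet been measured. It differs from compound 1 in one place: methyl in place of hydrogen on a saturated ring carbon. Among the measured compounds shown here, no measured pair isolates this change, and compound 2 combines it with a second alteration, so no clean guide exists. The step of a 1.3-fold lower number from compound 1 to compound 3 (0.13 log units; within the scatter) is expected to stay within the scatter, in no clear direction. The estimate for compound 3 in this assay is 1100 nM, between 400 nM and 3000 nM.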

Compound 3, half-maximal inhibitory concentration: 15 nM
Estimate against measurement, compound 3: 73-fold (1.87 log units) above; measured number outside the range, below it.
By their numbers in this assay, from the lowest: compound 3; then compounds 1 and 2 (each within the scatter of the next).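

Among the compounds shown here, the change from pyrrolidin-1-yl to 2-methylpyrrolidin-1-yl gives a 99-fold lower number from compound 1 to compound 3 (1.99 log units; beyond the scatter) in this assay and so isolates this single change for the first time. The position, on a saturated ring carbon next to the ring nitrogen, therefore responds strongly in this assay to one added carbon, a methyl with no ring, no hydrogen-bond donors or acceptors and no net charge. Nothing available explains why a change of this size produces so large a step.

Still open, going by these compounds, is whether the mirror-image form of the 2-methylpyrrolidin-1-yl group would give a similar number. On these data alone, it is equally open whether an ethyl or a hydroxymethyl group at this place, or a methyl on another carbon of the ring, would keep the gain seen with compound 3.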